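A few compounds are considered here, and "the series" means these few. Any claim that something is new, unique, unknown or untested is made for them only; others in the source may bear on it.

Two compounds built on a shared core that carries two phenyl groups have been tested in an assay on microsomes from liver for inhibition of sterol O-acyltransferase 1 (Rattus norvegicus); a higher number here means a weaker inhibitor, a lower number a stronger inhibitor. Compound 1 `CCCCCCn1nc(-c2ccccc2)c(-c2ccccc2)c(C)c1=O` gives 56000 nM. Compound 2 `CCCCCC(=O)Nc1cc(-c2ccccc2)c(-c2ccccc2)nn1` reaches only a limit of the assay, > 300000 nM. Compound 2 thus stands at the weak end of the numbers shown, at the limit of > 300000 nM in this assay, at which 1 of the 2 values shown sits. Compound 3 `CCCCCCCCOc1cc(-c2ccccc2)c(-c2ccccc2)nn1` differs from compound 2 in one place: octyloxy in place of (pentylcarbonyl)amino on an aromatic carbon. No measured step of this kind exists among these compounds, so the direction of the change is open. The expected step of an at least 1.5-fold lower number from compound 2 to compound 3 (0.17 log units; that floor lies within the scatter) is small, not beyond the usual scatter. Compound 3 is expected to give about 200000 nM, within a range from 40000 nM to 1000000 nM.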

Compound 3, half-maximal inhibitory concentration: 104000 nM
Compound 3: the middle estimate sits 1.9-fold (0.28 log units) above what was measured; low and high end bracket the measured number.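

Putting octyloxy in place of (pentylcarbonyl)amino on this aromatic carbon gives, in this assay, an at least 2.8-fold lower number from compound 2 to compound 3 (0.46 log units; beyond the scatter). So the number in this assay does respond to the group at this position, and this swap lowers it beyond the scatter. The full size of the step stays unknown, as compound 2 reaches only a limit of the assay and not a number: the limit of > 300000 nM in this assay, at which 1 of the 3 values shown sits.

The swap changes both the link to the ring and the chain, and the compounds shown do not separate the two. Going by these compounds, whether a shorter hexyloxy chain or a simple amine on this carbon would lower the number further remains open.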